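Cyano in place of hydrogen: second pair in the series

The compounds below may be only part of what the source reports. "The series", "measured", "known", "first", "only" and "open" are said of these compounds alone.

Compound 3 `COc1ccc2c(-c3cc(C(F)(F)F)cc(-c4cn(S(=O)(=O)c5ccc(C)cc5)c5cc(OC)ccc45)n3)cn(S(=O)(=O)c3ccc(C)cc3)c2c1` in a functional assay on P388 cells (Mus musculus) for inhibition, tested at 100 uM (on this read-out higher numbers stand for a stronger effect at the one concentration tested and lower numbers for a weaker effect), gives 99.9%. Compound 1 `COc1ccc2c(-c3cc(C(F)(F)F)c(C#N)c(-c4cn(S(=O)(=O)c5ccc(C)cc5)c5cc(OC)ccc45)n3)cn(S(=O)(=O)c3ccc(C)cc3)c2c1` differs from it by cyano in place of hydrogen on an aromatic carbon and in this assay compound 1 gives 3.8%, so the step is a number 96.1 percentage points lower from compound 3 to compound 1 (beyond the scatter). Compound 2 `Cc1ccc(S(=O)(=O)n2cc(-c3cc(C(F)(F)F)cc(-c4cn(S(=O)(=O)c5ccc(C)cc5)c5cc(Br)ccc45)n3)c3ccc(Br)cc32)cc1` in this assay gives 8.9%; the difference between the core of compound 2 and the core of compound 3 is not broken down here. Compound 4 `Cc1ccc(S(=O)(=O)n2cc(-c3cc(C(F)(F)F)c(C#N)c(-c4cn(S(=O)(=O)c5ccc(C)cc5)c5cc(Br)ccc45)n3)c3ccc(Br)cc32)cc1` has not been measured; it relates to compound 2 by cyano in place of hydrogen on an aromatic carbon, the same kind of change at a place described in the same words. Compound 2 starts from a value within the scatter of compound 1, so no room remains for a step of the earlier size. The step from compound 2 to compound 4 is expected to be about a number 4.9 percentage points lower from compound 2 to compound 4 (within the scatter). For compound 4 in this assay the estimate is 4%, expected between 0% and 15%.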

Compound 4, a percentage reported as inhibition, at one concentration (the size of the read-out at that concentration, not a potency): 1.3%
Beside the measured number, compound 4's estimate is 2.7 percentage points above it; the range from low to high includes it.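

In this assay, cyano in place of hydrogen on the aromatic carbon ortho to the trifluoromethyl group gives a number 7.6 percentage points lower from compound 2 to compound 4 (within the scatter). The change does not carry over with one step size from one core to the other: the same change on two cores in this assay, a number 96.1 percentage points lower (beyond the scatter) from compound 3 to compound 1 and a number 7.6 percentage points lower (within the scatter) from compound 2 to compound 4, 88.5 percentage points apart, beyond the scatter of two such steps. Compound 2 already gives 8.9%, which leaves little room for a lower number, and two pairs do not show whether the size of the step follows the starting value or the core itself.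

Still open, from the compounds shown here alone, is whether a group such as an amine or a carboxylic acid at this place would keep the effect seen for compound 3 . With a single concentration per compound, no potency can be read.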